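Extending the hydroxyalkyl ether on the shared core

This account rests on a few compounds, and the source may have more. Where it says the series, first, only, none or still open, it means among the compounds named here.

Compound 1 `CC(=O)O[C@@H]1[C@H](OC/C2=C/[C@@H]3[C@@H](C(C)C)CC=C(C)[C@@H]3C[C@H](OC(=O)/C=C/c3cn(C)cn3)[C@]3(C)C=C[C@@]2(O)O3)OC[C@@H](O)[C@H]1O` and compound 2 `CC(=O)O[C@@H]1[C@H](OC/C2=C/[C@@H]3[C@@H](C(C)C)CC=C(C)[C@@H]3C[C@H](OC(=O)/C=C/c3cn(C)cn3)[C@]3(C)C=C[C@@]2(OCCO)O3)OC[C@@H](O)[C@H]1O` share one core and differ only in 2-hydroxyethyl in place of hydrogen on an oxygen on a saturated carbon. In a functional assay on MCF7 cells (Homo sapiens), read by ELISA, with a stated time of 20 h (on this read-out higher numbers stand for weaker inhibition and lower numbers for stronger inhibition), compound 1 gives 20 nM and compound 2 gives 20 nM; the step of no change at the digits printed from compound 1 to compound 2 (within the scatter) lies within the scatter, so compound 2 stands level with compound 1 on the numbers at hand, with no other measured neighbour.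

Compound 3 `CC(=O)O[C@@H]1[C@H](OC/C2=C/[C@@H]3[C@@H](C(C)C)CC=C(C)[C@@H]3C[C@H](OC(=O)/C=C/c3cn(C)cn3)[C@]3(C)C=C[C@@]2(OCC(C)(C)CO)O3)OC[C@@H](O)[C@H]1O` carries the change (1-(hydroxymethyl)-1-methylethyl in place of hydroxymethyl on a saturated chain carbon bound to an oxygen on a saturated carbon). For the measured compounds named here, the only measured step that touches this part of the molecule is the one from compound 1 to compound 2, and it showed nothing beyond the scatter. On that basis the further change at the same place is expected to give a step of no change at the digits printed from compound 2 to compound 3 (within the scatter) in this assay that again stays within the scatter. Compound 3 is therefore estimated at 20 nM, with a range from 10 nM to 45 nM.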

Compound 3, half-maximal inhibitory concentration: 80 nM
Estimate against measurement, compound 3: 4.0-fold (0.60 log units) below, outside the stated range (above it).
By their numbers in this assay, from the lowest: compounds 1 and 2 (each within the scatter of the next); then compound 3.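

The ether position in this assay is not indifferent to what it carries: 1-(hydroxymethyl)-1-methylethyl in place of hydroxymethyl gives a 4.0-fold higher number from compound 2 to compound 3 (0.60 log units; beyond the scatter). Set against the unsubstituted hydroxyl, 2-(hydroxymethyl)-2-methylpropyl gives a 4.0-fold higher number from compound 1 to compound 3 (0.60 log units; beyond the scatter), so the flat result seen with 2-hydroxyethyl does not carry over to every hydroxyalkyl ether at this place, although the step is modest. Nothing in hand accounts for the higher number.

The branching and the greater chain length arrive together in this one change, so the compounds shown do not separate the two. A longer unbranched hydroxyalkyl chain would address that point, while an amine or a carboxylic acid in place of the terminal hydroxyl remains an open question at this position.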